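The compounds below may be only part of what the source reports. "The series", "measured", "known", "first", "only" and "open" are said of these compounds alone.

Compound 1 `O=C1CSC(c2cccc(Cl)c2)N1CCN1CCCCC1`: 77%
Compound 2 `O=C1CSC(c2ccccc2[N+](=O)[O-])N1CCN1CCCCC1`: 100%

Of the compounds shown here, two have been measured in an ADME assay on Vero cells (Chlorocebus sabaeus) for cytotoxicity, read by neutral red uptake, tested at 197 ug/mL; on this read-out higher numbers stand for a weaker effect at the one concentration tested and lower numbers for a stronger effect. Compound 1 gives the lowest of the two numbers, 77%. The nearest value belongs to compound 2, which gives 100%, a number higher by more than the usual scatter. Compound 3 `Cc1ccc(C2SCC(=O)N2CCN2CCCCC2)cc1` has not yet been tested in this assay. It differs from compound 1 in one place: 4-methylphenyl in place of 3-chlorophenyl on a saturated ring carbon. Among the measured compounds shown here, no pair of measured compounds shares this change, so nothing measured tells how large its effect is. Since compound 1 gives 77% and compound 2 gives 100%, the read-out for compound 3 is expected to sit between the two, a small step upward from compound 1, a number 9 percentage points higher from compound 1 to compound 3 (within the scatter), at or just beyond the scatter. In this assay compound 3 is estimated at 86%, with a range from 68% to 100%.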

Compound 3, a percentage reported as activity, at one concentration (the size of the read-out at that concentration, not a potency): 85%
The estimate for compound 3 lay 1 percentage points above the measured number, within the range that was stated.
By their numbers in this assay, from the lowest: compounds 1 and 3 (each within the scatter of the next); then compound 2.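

In this assay, among the compounds shown here, replacing 3-chlorophenyl with 4-methylphenyl on the saturated ring carbon gives a number 8 percentage points higher from compound 1 to compound 3 (within the scatter), the only step so far that can be read at this position. The two groups therefore cannot be told apart by this read-out, so at this position a chlorine can give way to a methyl, with the attachment point on the phenyl ring changing as well, without a step beyond the scatter. No measurement at hand accounts for this result.

This single step cannot show whether the change of atom or the change of ring position matters more, as the two travel together. Also open, from the compounds shown here alone, is how the read-out would respond to a carboxylic acid or an amine on the phenyl ring, or to a morpholine in place of the piperidine.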